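The source may hold more compounds than are shown below. What is called first, only, known or untested is meant among the compounds shown, and "the series" means these compounds.

In a functional assay (aorta) with Oryctolagus cuniculus as the target (a lower number here means tighter binding, a higher number weaker binding), three compounds with a shared core have been measured. Compound 1 (`N#Cc1ccc(OCCCN2CCC(C(c3ccc(F)cc3)c3ccc(F)cc3)CC2)cc1`) gives 5.01 nM, compound 2 (`COc1ccc(OCCCN2CCC(C(c3ccc(F)cc3)c3ccc(F)cc3)CC2)cc1`) gives 2.51 nM, and compound 3 (`Fc1ccc(C(c2ccc(F)cc2)C2CCN(CCCOc3cccc4ccccc34)CC2)cc1`) gives 5.01 nM. Compound 3 thus stands level with compound 1 at the digits reported, and its value lies within the scatter of both others.

Compound 4 (`O=S(=O)(CCCN1CCC(C(c2ccc(F)cc2)c2ccc(F)cc2)CC1)c1ccccc1`) has phenylsulfonyl in place of (naphthalen-1-yl)oxy on a saturated chain carbon, three bonds along the chain from an amine nitrogen in a ring.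

The nearest evidence comes from changes to the aromatic group on the oxygen: a 2.0-fold lower number from compound 1 to compound 2 (0.30 log units; within the scatter), no change at the digits printed from compound 1 to compound 3 (within the scatter), and a 2.0-fold higher number from compound 2 to compound 3 (0.30 log units; within the scatter). All three stay within the scatter, but none replaces the oxygen itself, so the data do not test this change directly. No step beyond the scatter is therefore expected in this assay, though the uncertainty is wide. The expected change is a 1.4-fold higher number from compound 3 to compound 4 (0.15 log units; within the scatter). Compound 4 is estimated at 7 nM, with an expected range of 2.5 nM to 25 nM.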

Compound 4, dissociation constant: 20 nM
The estimate for compound 4 lay 2.9-fold (0.46 log units) below the measured number; the measured number falls inside the stated range.
By their numbers in this assay, from the lowest: compounds 2, 1 and 3 (each within the scatter of the next); then compound 4.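

In this assay, replacing the oxygen link is the first change shown to move the number beyond the scatter: there is a 4.0-fold higher number from compound 3 to compound 4 (0.60 log units; beyond the scatter) and a 4.0-fold higher number from compound 1 to compound 4 (0.60 log units; beyond the scatter) and an 8.0-fold higher number from compound 2 to compound 4 (0.90 log units; beyond the scatter). Changes to the aromatic group on the oxygen had stayed within the scatter, whereas phenylsulfonyl on this saturated chain carbon gives a higher number than each of the three aryloxy groups shown. Nothing available here accounts for this step.

The compounds shown leave open whether the higher number belongs to the sulfonyl link itself or to the plain phenyl ring it carries, as no aryloxy partner has that same ring. Phenoxy, phenylthio or benzoyl at this place would separate the two.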